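Methoxy to Dimethylamino: Expected Shift in MRC5 Inhibition

A few compounds are considered here, and "the series" means these few. Any claim that something is new, unique, unknown or untested is made for them only; others in the source may bear on it.

Compound 1, `CN(C)c1ncnc2c1c(-c1ccsc1)cn2[C@@H]1O[C@H](CO)[C@@H](O)[C@H]1O`: in an ADME assay on MRC5 cells (Homo sapiens), read by MTT assay, with a stated time of 72 h (a higher number here means a weaker inhibitor, a lower number a stronger inhibitor), compound 1 sits at a limit, > 100000 nM.
Compound 2, `COc1ncnc2c1c(-c1ccoc1)cn2[C@@H]1O[C@H](CO)[C@@H](O)[C@H]1O`: compound 2 gives 29400 nM.
Compound 3, `COc1ncnc2c1c(-c1cccs1)cn2[C@@H]1O[C@H](CO)[C@@H](O)[C@H]1O`: compound 3 gives 43200 nM.

Compound 3 stands at the higher of the two numbers given, but the step of a 1.5-fold higher number from compound 2 to compound 3 (0.17 log units; within the scatter) is within the scatter, so compounds 2 and 3 cannot be told apart. Compound 1 sits at a limit, (the limit of > 100000 nM in this assay, at which 1 of the 3 values shown sits).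

Compound 4, `CN(C)c1ncnc2c1c(-c1cccs1)cn2[C@@H]1O[C@H](CO)[C@@H](O)[C@H]1O`, is not yet measured. It differs from compound 3 by dimethylamino in place of methoxy on an aromatic carbon. Within the data shown here, no measured step covers this change: the one measured step, a 1.5-fold higher number from compound 2 to compound 3 (0.17 log units; within the scatter), concerns the five-membered ring and is within the scatter. Among the measured compounds shown here, compound 1 also carries dimethylamino, and its value is a limit, but compound 1 differs from compound 3 in two places, so no step between them is given.

Compound 4 is therefore expected to give a higher number than compound 3, around 90000 nM. The expected range for compound 4 runs from 40000 nM to 200000 nM, with a real chance that only a limit is reported. This expectation amounts to a step of a 2.1-fold higher number from compound 3 to compound 4 (0.32 log units; beyond the scatter).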

Compound 4, half-maximal inhibitory concentration: > 100000 nM
Compound 4: no number, only a limit; the forecaster's own chance of this, stated with the estimate: 50%; at least 1.1-fold (0.04 log units) between middle value and limit.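

The place on the six-membered aromatic ring that held methoxy now has a step that can be read: with dimethylamino in its stead, this assay gives an at least 2.3-fold higher number from compound 3 to compound 4 (0.36 log units; beyond the scatter). Compound 4 gives no number, only a limit, so this step has a floor but no known full size. Compound 1 and compound 4, the two compounds with dimethylamino, both stand at the same limit, whichever thiophene they carry: the limit of > 100000 nM in this assay, at which 2 of the 4 values shown sit.

The step between compound 1 and compound 4 cannot be read, so the compounds shown leave open whether thiophen-2-yl and thiophen-3-yl differ when dimethylamino is present. They also leave open how a primary amine or a longer chain such as ethoxy would behave at this place in this assay.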